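A few compounds are considered here, and "the series" means these few. Any claim that something is new, unique, unknown or untested is made for them only; others in the source may bear on it.

Compound 1 is `Cc1cccc(C)c1NC(=O)CSc1nnc(-c2ccoc2C)n1Cc1ccco1`. In a functional assay on CHO cells for antagonist activity at Orexin receptor type 2 (Homo sapiens), read by FLIPR and calcium flux (on this read-out higher numbers stand for weaker inhibition and lower numbers for stronger inhibition), compound 1 gives > 15800 nM, which is a limit of the assay and not a number. Compound 2 is `Cc1cccc(NC(=O)CSc2nnc(-c3ccoc3C)n2Cc2ccco2)c1C`. In this assay compound 2 gives > 15800 nM, again a limit rather than a number. Compound 3 is `Cc1cccc(NC(=O)CSc2nnc(-c3ccoc3C)n2Cc2ccco2)c1`. In this assay compound 3 gives 50.1 nM.

Among the compounds with values here, compound 3 therefore holds the only real number in this set; the other two sit at the limit of > 15800 nM in this assay, at which 2 of the 3 values shown sit. Compound 4 is `Cc1occc1-c1nnc(SCC(=O)Nc2cccc(Cl)c2)n1Cc1ccco1` and has not yet been measured. It differs from compound 3 by chloro in place of methyl on an aromatic carbon. Within the data shown here, the measured steps that touch this ring are an at least 310-fold lower number from compound 1 to compound 3 (2.49 log units; beyond the scatter) and an at least 310-fold lower number from compound 2 to compound 3 (2.49 log units; beyond the scatter); both remove a methyl from the ring and neither swaps methyl for chloro, so they show only that this ring is sensitive to change. The step that the two limits leave unreadable from compound 1 to compound 2 cannot be read. Among the measured compounds shown here, with no direct precedent, the expectation for compound 4 is a step of a 1.0-fold lower number from compound 3 to compound 4 (0.00 log units; within the scatter), within the scatter. Compound 4 is thus estimated at 50 nM, between 15 nM and 160 nM.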

Compound 4, inhibition constant: 63.1 nM
Beside the measured number, compound 4's estimate is 1.3-fold (0.10 log units) below it, and the stated range covers the measured number.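

Within the data shown here, the earlier compounds showed only that this ring responds when a methyl is removed; here chloro takes the place of the methyl of the 3-methylphenyl group, and in this assay the result is a 1.3-fold higher number from compound 3 to compound 4 (0.10 log units; within the scatter), so the two groups cannot be told apart at this position. The large steps also hold with chloro on the ring, at an at least 250-fold lower number from compound 2 to compound 4 (2.39 log units; beyond the scatter) and an at least 250-fold lower number from compound 1 to compound 4 (2.39 log units; beyond the scatter), so the gap to the dimethylphenyl compounds does not rest on the 3-methylphenyl group alone. Both of those steps start from limits of the assay rather than numbers: the limit of > 15800 nM in this assay, at which 2 of the 4 values shown sit.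

The compounds shown leave open whether a methoxy, an amine or a carboxylic acid at this position would give a similar number. They also leave open what a plain phenyl, with neither methyl nor chloro, would give.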